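This account rests on a few compounds, and the source may have more. Where it says the series, first, only, none or still open, it means among the compounds named here.

Of the compounds shown here, three built on one shared core have been tested in a functional assay on MDA-MB-231 cells (Homo sapiens) for antiproliferative activity, read by MTT assay, with a stated time of 72 h; a lower number here means a stronger inhibitor, a higher number a weaker inhibitor. Compound 1 `O=C(CCc1cccc2c1B(O)OC2)Nc1ccc(Br)cc1` gives 5300 nM, compound 2 `O=C(CCc1cccc2c1B(O)OC2)Nc1ccc(I)cc1` gives 33000 nM, and compound 3 `O=C(CCc1cccc2c1B(O)OC2)Nc1cccc(Br)c1` gives 720 nM. Compound 2 carries iodo in place of bromo on an aromatic carbon, and the step of a 6.2-fold higher number from compound 1 to compound 2 (0.79 log units; beyond the scatter). Compound 3 differs from compound 1 by 3-bromophenyl in place of 4-bromophenyl on an amide-type nitrogen, and the step of a 7.4-fold lower number from compound 1 to compound 3 (0.87 log units; beyond the scatter); the step of a 46-fold lower number from compound 2 to compound 3 (1.66 log units; beyond the scatter) is the widest among the three. Compound 4 `O=C(CCc1cccc2c1B(O)OC2)Nc1cccc(I)c1` has not yet been measured; it differs from compound 3 by iodo in place of bromo on an aromatic carbon. For the measured compounds named here, this is the same kind of change as the one leading to compound 2, but there the place was para to a large group, whereas here it is meta to a large group. The expected step is a 3.5-fold higher number from compound 3 to compound 4 (0.54 log units; beyond the scatter). That expectation rests on the earlier step of a 6.2-fold higher number from compound 1 to compound 2 (0.79 log units; beyond the scatter), weakened somewhat since the surroundings of the place differ. Compound 4 is therefore estimated at 2500 nM, likely between 700 nM and 9000 nM.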

Compound 4, half-maximal inhibitory concentration: 5300 nM
Compound 4: the middle estimate sits 2.1-fold (0.33 log units) below what was measured; measured number inside the range.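

In this assay the swap of bromo for iodo gives a 7.4-fold higher number from compound 3 to compound 4 (0.87 log units; beyond the scatter) and this step agrees with the earlier one: the same change on two cores in this assay, a 6.2-fold higher number (0.79 log units; beyond the scatter) from compound 1 to compound 2 and a 7.4-fold higher number (0.87 log units; beyond the scatter) from compound 3 to compound 4, 1.2-fold (0.07 log units) apart, within the scatter of two such steps. Elsewhere, 3-iodophenyl in place of 4-iodophenyl gives a 6.2-fold lower number from compound 2 to compound 4 (0.79 log units; beyond the scatter) while 3-iodophenyl in place of 4-bromophenyl gives no change at the digits printed from compound 1 to compound 4 (within the scatter). So the size of the swap carried over between these two cores, but two pairs in one cell assay cannot show why it did, or whether it would hold on any other core.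

The compounds shown leave open how a chloro group or an amine in the same place would compare with bromo and iodo.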